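Cytotoxicity Limits Across Four Related Compounds

The source may hold more compounds than are shown below. What is called first, only, known or untested is meant among the compounds shown, and "the series" means these compounds.

Compound 1 `CC(C)N(Cc1cccc(OCCCCCC(=O)O)c1)C(=O)c1ccc(-c2cccc(OC(F)(F)F)c2)cc1` was tested in an ADME assay on HepG2 cells (Homo sapiens) for cytotoxicity, read by CellTiter-Glo and resazurin assay, with a stated time of 72 h; on this read-out higher numbers stand for an effect only at larger amounts of compound and lower numbers for an effect already at smaller amounts. In this assay compound 1 gives > 26000 nM, which is a limit of the assay rather than a number. Compound 2 `COc1cc(F)cc(-c2ccc(C(=O)N(Cc3cccc(OCCCCCC(=O)O)c3)C(C)C)cc2)c1` carries a single change from compound 1: 3-fluoro-5-methoxyphenyl in place of 3-(trifluoromethoxy)phenyl on an aromatic carbon. In this assay compound 2 also gives > 26000 nM, again only a limit. The step that the two limits leave unreadable from compound 1 to compound 2 therefore cannot be sized, because of the limit of > 26000 nM in this assay, at which 3 of the 3 values shown sit. Compound 3 `CCOC(=O)CCCCCOc1cccc(CN(C(=O)c2ccc(-c3cccc(OC(F)(F)F)c3)cc2)C(C)C)c1` differs from compound 1 in another place, (ethyl in place of hydrogen on an oxygen next to a carbonyl group), and in this assay compound 3 gives > 26000 nM, once more a limit, so a step that the two limits leave unreadable from compound 1 to compound 3 is equally unreadable.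

Compound 4 `CCOC(=O)CCCCCOc1cccc(CN(C(=O)c2ccc(-c3cc(F)cc(OC)c3)cc2)C(C)C)c1` has not yet been measured. It stands to compound 3 as compound 2 stands to compound 1: 3-fluoro-5-methoxyphenyl in place of 3-(trifluoromethoxy)phenyl on an aromatic carbon, the same change at the same place. Because all three measured values sit at the limit of > 26000 nM in this assay, at which 3 of the 3 values shown sit, the step from compound 3 to compound 4 is expected to be small, a step that the limit leaves unreadable from compound 3 to compound 4. Compound 4 is accordingly estimated to give 30000 nM in this assay, most likely reported again only as a limit.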

Compound 4, half-maximal effective concentration: > 26000 nM
Compound 4 gave a limit, no number; the forecaster's own chance of this, stated with the estimate: 85%; the middle value is on the limit's open side.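

In this assay compound 4 gives > 26000 nM, which is a limit of the assay and not a number. No step from compound 2 or compound 3 to compound 4 can therefore be read: the limit of > 26000 nM in this assay, at which 4 of the 4 values shown sit.

The compounds shown leave open at what concentration, if any, compound 1, compound 2, compound 3 or compound 4 would harm the cells, and whether their effects differ.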